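Methylsulfanyl for dimethylamino on a three-compound series

A few compounds are considered here, and "the series" means these few. Any claim that something is new, unique, unknown or untested is made for them only; others in the source may bear on it.

Measured in a functional assay on UV4 cells (Cricetulus griseus) for cytotoxicity, with a stated time of 4 h; a higher number here means a weaker inhibitor, a lower number a stronger inhibitor:
compound 1 `CS(=O)(=O)N1CC(CCl)c2ccc(N)cc21`: 13000 nM
compound 2 `CNc1ccc2c(c1)N(S(C)(=O)=O)CC2CCl`: 4100 nM
compound 3 `CN(C)c1ccc2c(c1)N(S(C)(=O)=O)CC2CCl`: 15000 nM

Compound 3 gives the highest of the three numbers. Its gap to compound 1, a 1.2-fold higher number from compound 1 to compound 3 (0.06 log units; within the scatter), is within the scatter, so the two cannot be ordered. The step of a 3.7-fold higher number from compound 2 to compound 3 (0.56 log units; beyond the scatter) is beyond the scatter, and the same methylation in the other direction, a 3.2-fold lower number from compound 1 to compound 2 (0.50 log units; beyond the scatter), is of like size the other way; both steps concern a methyl on the ring nitrogen, not the atom carried by the aromatic carbon.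

Compound 4 `CSc1ccc2c(c1)N(S(C)(=O)=O)CC2CCl` differs from compound 3 by methylsulfanyl in place of dimethylamino on an aromatic carbon. Among the compounds with values here, no measured step swaps the nitrogen of the amino group for sulfur; the only change on that aromatic carbon, a 1.2-fold higher number from compound 1 to compound 3 (0.06 log units; within the scatter), is within the scatter. The series therefore gives no ground for a step in either direction in this assay, and a step of no size beyond the scatter is expected, with a wide range to reflect the lack of a comparable step.

Compound 4 is estimated at 15000 nM, within 4000 nM to 50000 nM, which means an expected step of no change at the digits printed from compound 3 to compound 4 (within the scatter).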

Compound 4, half-maximal inhibitory concentration: > 200000 nM
Compound 4 was reported as a limit; the forecaster's own chance of this, stated with the estimate: 10%; at least 13-fold (1.12 log units) between middle value and limit.
By their numbers in this assay, from the lowest: compound 2; then compounds 1 and 3 (each within the scatter of the next). At a limit, above all of these: compound 4.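

In this assay compound 4 stands as a limit and not as a number: the limit of > 200000 nM in this assay, at which 1 of the 4 values shown sits.

Methylsulfanyl on this aromatic carbon gives the first large change in the series, with an at least 13-fold higher number from compound 3 to compound 4 (1.12 log units; beyond the scatter), and the picture is the same against the other two nitrogen-linked groups, with an at least 48-fold higher number from compound 2 to compound 4 (1.68 log units; beyond the scatter) and an at least 15-fold higher number from compound 1 to compound 4 (1.18 log units; beyond the scatter). Among amino, methylamino and dimethylamino, the steps were modest or within the scatter, so in these four compounds replacing the nitrogen-linked group with the sulfur-linked one counts for far more than the number of methyls on the nitrogen.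

With a single sulfur-linked group in hand, the compounds shown leave open whether the large step follows from the presence of sulfur or from the loss of nitrogen at this position. A methoxy group or a plain ethyl chain on the same aromatic carbon would help separate these two readings, and an acetamido group would show whether a nitrogen-linked group with a carbonyl keeps the numbers of compounds 1, 2 and 3.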